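Lengthening a chain on a compound at the limit

The compounds below may be only part of what the source reports. "The series", "measured", "known", "first", "only" and "open" are said of these compounds alone.

- Compound 1 `CCCN(C)c1nc(Cc2c(F)cccc2F)cc(=O)[nH]1` gives 85000 nM as a measured number
- Compound 2 `CCCN(C)c1nc(Cc2c(F)cccc2F)c(C)c(=O)[nH]1` gives > 81000 nM as a limit

In an ADME assay on MT4 cells (Homo sapiens) for cytotoxicity, read by MTT assay, with a stated time of 4 days (on this read-out higher numbers stand for lower toxicity in this test and lower numbers for higher toxicity in this test), compound 2 gives > 81000 nM and this is a limit of the assay, not a number. The change to compound 3 `CCCN(CCC)c1nc(Cc2c(F)cccc2F)c(C)c(=O)[nH]1` is ethyl in place of hydrogen on a saturated chain carbon bound to a nitrogen on an aromatic ring and turns methyl(propyl)amino into dipropylamino. Among the measured compounds shown here, the only measured step is a step that the limit leaves unreadable from compound 1 to compound 2 and it concerns methyl in place of hydrogen on an aromatic carbon, a different change. With no size to carry over, no step beyond the scatter is expected. Going by these compounds, the estimated step is an at least 1.1-fold lower number from compound 2 to compound 3 (0.06 log units; that floor lies within the scatter) and its direction remains open. Compound 3 is expected at 70000 nM with an estimated range from 30000 nM to 140000 nM in this test.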

Compound 3, half-maximal cytotoxic concentration: > 74000 nM
Compound 3: no number, only a limit (the forecaster's own chance of this, stated with the estimate: 45%); middle value at least 1.0-fold (0.02 log units) from the limit.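

In this assay, among the compounds shown here, compound 2 and compound 3 each give only a limit, not a number, so no step between them can be read. Going by these compounds, whether dipropylamino and methyl(propyl)amino differ in this test stays open.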